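The compounds below may be only part of what the source reports. "The series", "measured", "known", "first", "only" and "open" are said of these compounds alone.

Measured so far:
Compound 1, `CCN(Cc1ccccc1)c1cccc(C(=O)N2CCc3ccc(OS(N)(=O)=O)cc3C2)c1`, gives 69%.
Compound 2, `NS(=O)(=O)Oc1ccc2c(c1)CN(C(=O)c1ccc(N(Cc3ccccc3)Cc3ccco3)cc1)CC2`, gives 98.2%.
Compound 3, `CC(C)CCN(CCC(C)C)c1ccc(C(=O)N2CCc3ccc(OS(N)(=O)=O)cc3C2)cc1`, gives 90.8%.

All three share a core carrying a sulfamate, and all were tested in an assay on HEK293 cells for inhibition of Steryl-sulfatase (Homo sapiens), tested at 1 uM; on this read-out higher numbers stand for a stronger effect at the one concentration tested and lower numbers for a weaker effect. Compound 3 stands second highest of the three numbers. Its nearest neighbour is compound 2, whose value of 98.2% lies within the usual scatter of compound 3, so the two cannot be told apart. Its furthest is compound 1, whose value of 69% lies well beyond the scatter below compound 3.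

The next compound, compound 4, `CCN(Cc1ccncc1)c1ccc(C(=O)N2CCc3ccc(OS(N)(=O)=O)cc3C2)cc1`, has not yet been measured. Compared with compound 3 it carries one change: ethyl((pyridin-4-yl)methyl)amino in place of diisopentylamino on an aromatic carbon. The group that leaves is a branched chain pair with no ring; the group that enters is smaller and brings an aromatic ring with a nitrogen in it, giving one more hydrogen-bond acceptor.

For the measured compounds named here, no pair of measured compounds differs in exactly this way, so the expected step rests only on the spread of the three values. The drop is expected to be modest, as a number 12.8 percentage points lower from compound 3 to compound 4 (beyond the scatter), probably staying on the stronger side of compound 1. The estimate for compound 4 is therefore 78%, expected to fall between 55% and 92%.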

Compound 4, a percentage reported as inhibition, at one concentration (the size of the read-out at that concentration, not a potency): 86.6%
Compound 4: the middle estimate sits 8.6 percentage points below what was measured; the range from low to high includes it.
By their numbers in this assay, from the lowest: compound 1; then compounds 4, 3 and 2 (each within the scatter of the next, the first and the last beyond it).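

In this assay the exchange of diisopentylamino for ethyl((pyridin-4-yl)methyl)amino on this aromatic carbon amounts to a number 4.2 percentage points lower from compound 3 to compound 4 (within the scatter) and so leaves the two compounds indistinguishable. For the compounds shown here, this is the first direct comparison at this position, and it shows that a pair of branched chains with no ring and a group holding a six-membered aromatic ring with a nitrogen in it can read alike, even though the entering group adds a hydrogen-bond acceptor. Nothing measured here explains why the two compounds read alike, and a reading at one concentration is not a potency.

The compounds shown leave open how far the group on this carbon can be cut back or changed in kind, for example to a bare amine or a carboxylic acid, both of which would test whether a large substituted amino group is needed at all. They also leave open whether the ring nitrogen itself matters, a question that a pyridin-3-ylmethyl group in the same place could begin to address.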